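Swapping the hydrazone aryl group on a shared core

A few compounds are considered here, and "the series" means these few. Any claim that something is new, unique, unknown or untested is made for them only; others in the source may bear on it.

Compound 1 `CN(C)CCn1cnnc1-c1cc(Oc2ccc(NC(=O)N/N=C/c3c(O)ccc4ccccc34)cc2F)ccn1` is tested in a functional assay on NCI-H460 cells (Homo sapiens) for cytotoxicity, read by MTT assay, with a stated time of 72 h (on this read-out lower numbers stand for stronger inhibition and higher numbers for weaker inhibition), where compound 1 gives 890 nM. Compound 2 `CN(C)CCn1cnnc1-c1cc(Oc2ccc(NC(=O)N/N=C/c3ccccc3O[N+](=O)[O-])cc2F)ccn1` keeps the whole core and changes only the aryl group hanging from the carbon with a double bond to nitrogen; in this assay compound 2 gives 1270 nM. The step of a 1.4-fold higher number from compound 1 to compound 2 (0.15 log units; within the scatter) shows that these two numbers sit within the usual scatter of each other, so compound 2 does not stand apart from compound 1 on the numbers seen so far.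

Compound 3 `Cc1cc(/C=N/NC(=O)Nc2ccc(Oc3ccnc(-c4nncn4CCN(C)C)c3)c(F)c2)cc(C)c1O` makes a further change at the same place: 4-hydroxy-3,5-dimethylphenyl in place of 2-(nitrooxy)phenyl on a carbon with a double bond to nitrogen. Among the compounds with values here, the only measured step that bears on this position is the one from compound 1 to compound 2, and that step was within the scatter. With no sign yet that this position moves the read-out, the expected step of a 1.2-fold lower number from compound 2 to compound 3 (0.06 log units; within the scatter) is none beyond the scatter. Compound 3 is therefore estimated at 1100 nM in this assay, with a range from 400 nM to 3000 nM.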

Compound 3, half-maximal inhibitory concentration: 2010 nM
The estimate for compound 3 lay 1.8-fold (0.26 log units) below the measured number; the range from low to high includes it.
By their numbers in this assay, from the lowest: compounds 1, 2 and 3 (each within the scatter of the next, the first and the last beyond it).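

In this assay, this position now gives its first step beyond the scatter, when 4-hydroxy-3,5-dimethylphenyl takes the place of 2-hydroxynaphthalen-1-yl on the carbon with a double bond to nitrogen (a 2.3-fold higher number from compound 1 to compound 3 (0.35 log units; beyond the scatter)), so the aryl group here can move the read-out, if only modestly. The change from 2-(nitrooxy)phenyl to 4-hydroxy-3,5-dimethylphenyl does not separate its two compounds (a 1.6-fold higher number from compound 2 to compound 3 (0.20 log units; within the scatter)), which means that only the two ends of this short series can be told apart, while compound 2 cannot be distinguished from either of them. No measurement is available to explain the difference seen between the 2-hydroxynaphthalen-1-yl and 4-hydroxy-3,5-dimethylphenyl groups.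

The compounds shown leave open whether a phenyl ring carrying an amine or a carboxylic acid, or a saturated ring such as cyclohexyl, would shift the number further in this place, and in which direction. The rest of the shared core stays the same in all three compounds, so the effect of a longer chain on the triazole-bearing side remains an open question as well.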